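Replacing 4-fluorophenyl with pyridin-4-yl in compound 3

The source may hold more compounds than are shown below. What is called first, only, known or untested is meant among the compounds shown, and "the series" means these compounds.

Compound 1 (`COc1cc(/N=C/c2cccs2)ccc1-c1cnco1`) gives 406000 nM in an ADME assay on Vero cells (Chlorocebus sabaeus) for cytotoxicity, read by MTT assay, with a stated time of 96 h; on this read-out lower numbers stand for higher toxicity in this test and higher numbers for lower toxicity in this test
Compound 2 (`COc1cc(/N=C/c2ccc(F)cc2)ccc1-c1cnco1`) gives 325000 nM in this assay

Within the data shown here, compound 2 stands level with compound 1, the only other compound measured so far, since their two values lie within the scatter of each other. Compound 3 (`COc1cc(/N=C/c2ccncc2)ccc1-c1cnco1`) has not yet been measured. It differs from compound 2 by a single exchange, pyridin-4-yl in place of 4-fluorophenyl on a carbon with a double bond to nitrogen. Among the measured compounds shown here, the one measured step that bears on this exchange concerns the same carbon, with 4-fluorophenyl in place of thiophen-2-yl (a 1.2-fold lower number from compound 1 to compound 2 (0.10 log units; within the scatter)), and it stays within the scatter. For the measured compounds named here, this is thin evidence, and no measured compound carries pyridin-4-yl. Even so, the expectation in this assay is for no change beyond the scatter, and the estimated step is small (a 1.1-fold higher number from compound 2 to compound 3 (0.03 log units; within the scatter)). Compound 3 is expected to give 350000 nM within an estimated range of 160000 nM to 750000 nM once it is measured.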

Compound 3, half-maximal cytotoxic concentration: 239000 nM
The estimate for compound 3 lay 1.5-fold (0.17 log units) above the measured number; low and high end bracket the measured number.
By their numbers in this assay, from the lowest: compounds 3, 2 and 1 (each within the scatter of the next).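

In this assay, moving from a carbon-only aromatic ring to pyridin-4-yl on the carbon with a double bond to nitrogen gives a 1.4-fold lower number from compound 2 to compound 3 (0.13 log units; within the scatter) and so brings no change that can be told from the scatter, although the entering group counts one hydrogen-bond acceptor and the leaving 4-fluorophenyl none. Against thiophen-2-yl, the same group gives a 1.7-fold lower number from compound 1 to compound 3 (0.23 log units; within the scatter) and this, the widest gap among the three compounds, also fails to separate them, so this place has now taken three different aromatic rings without a step beyond the scatter in this assay. No measurement at hand accounts for the small differences between these numbers.

From the compounds shown here alone, all three compounds carry an aromatic ring on this carbon, so it remains open whether a group of another kind there, such as a saturated amine, a carboxylic acid or a longer alkyl chain, would move the number beyond the scatter. They also share the rest of the core unchanged, which leaves open what an exchange elsewhere on it would do in this assay.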